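Swapping the amide aryl group in a weak HeLa inhibitor

The source may hold more compounds than are shown below. What is called first, only, known or untested is meant among the compounds shown, and "the series" means these compounds.

Compound 3 `Cn1cc(-c2cnc(N)c(Oc3ccc(C(=O)Nc4ccccc4Cl)cc3)n2)cn1` gives 73000 nM in a functional assay on HeLa cells (Homo sapiens) for inhibition, read by MTT assay, with a stated time of 72 h (a higher number here means a weaker inhibitor, a lower number a stronger inhibitor), the second highest of three numbers: compound 2 `Cc1noc(C)c1-c1cnc(N)c(Oc2ccc(C(=O)Nc3ccccc3Cl)cc2)n1` gives 81300 nM, and compound 1 `Cc1noc(C)c1-c1cnc(N)c(Oc2ccc(C(=O)NC3CCCCC3)cc2)n1` gives 26100 nM. Compound 4 `Cn1cc(-c2cnc(N)c(Oc3ccc(C(=O)Nc4cc(Cl)ccn4)cc3)n2)cn1` differs from compound 3 by 4-chloropyridin-2-yl in place of 2-chlorophenyl on an amide-type nitrogen. Among the measured compounds shown here, only one measured step touches this amide nitrogen: a 3.1-fold higher number from compound 1 to compound 2 (0.49 log units; beyond the scatter). The other step, a 1.1-fold lower number from compound 2 to compound 3 (0.05 log units; within the scatter), concerns the aromatic carbon and does not bear on it. Changes on the amide nitrogen have so far moved this assay only modestly, so a step of a 1.2-fold lower number from compound 3 to compound 4 (0.09 log units; within the scatter) is expected, small and of uncertain direction. Compound 4 is therefore estimated at 60000 nM, within 25000 nM to 150000 nM.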

Compound 4, half-maximal inhibitory concentration: 40800 nM
Beside the measured number, compound 4's estimate is 1.5-fold (0.17 log units) above it; the measured number falls inside the stated range.
By their numbers in this assay, from the lowest: compounds 1, 4, 3 and 2 (each within the scatter of the next, the first and the last beyond it).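

Placing 4-chloropyridin-2-yl in place of 2-chlorophenyl on the amide-type nitrogen gives a 1.8-fold lower number from compound 3 to compound 4 (0.25 log units; within the scatter) in this assay, so a ring with a hetero atom is accommodated here without a step beyond the scatter. Unlike the earlier change on this nitrogen, from cyclohexyl to 2-chlorophenyl, this one swaps one aromatic ring for another. No supporting data explain the result.

As far as these compounds go, it remains open whether a carboxylic acid or an amine on this aryl group would give a number well below that of compound 1 at 26100 nM in this assay. From the compounds shown here alone, it is also open whether 4-chloropyridin-2-yl would behave alike alongside 3,5-dimethyl-1,2-oxazol-4-yl on the aromatic carbon.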